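The source may hold more compounds than are shown below. What is called first, only, known or untested is meant among the compounds shown, and "the series" means these compounds.

Measured so far in an assay for inhibition of epoxide hydrolase 1 (Homo sapiens), read by fluorescence, using microsomes; a higher number here means a weaker inhibitor, a lower number a stronger inhibitor:
Compound 1 `Cc1ccccc1NC(=S)NC(=O)c1ccccc1`: 3540 nM
Compound 2 `CC(=O)NC(=S)Nc1ccccc1`: 2350 nM

Of the two numbers, that of compound 2 is the smaller, but the gap to compound 1 lies within the usual scatter, so no real difference between them can be claimed. Compound 3 `CC(=O)NC(=S)Nc1ccccc1C` is next to be tested in this assay. It differs from compound 2 in a single spot: methyl in place of hydrogen on an aromatic carbon. Going by the values given here, no measured pair shows what this change does here. A step no larger than the scatter is expected for a 1.1-fold higher number from compound 2 to compound 3 (0.03 log units; within the scatter), in either direction. Compound 3 is therefore estimated at 2500 nM, within a range from 1000 nM to 6500 nM.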

Compound 3, half-maximal inhibitory concentration: 1500 nM
Estimate against measurement, compound 3: 1.7-fold (0.22 log units) above, within the range that was stated.
By their numbers in this assay, from the lowest: compounds 3, 2 and 1 (each within the scatter of the next, the first and the last beyond it).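

In this assay, methyl on this aromatic carbon, ortho to a group of 7 heavy atoms, gives a 1.6-fold lower number from compound 2 to compound 3 (0.19 log units; within the scatter), so the position takes this small group without a real gain or loss. Methyl in place of phenyl on the carbonyl carbon gives a 2.4-fold lower number from compound 1 to compound 3 (0.37 log units; beyond the scatter), the first step here beyond the scatter, though a modest one. Nothing available explains either step. Still open, on these data alone, is what a longer chain such as propyl would do on the aromatic carbon, or what an amine would do on the carbonyl carbon.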